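Amino for methyl on the five-membered ring: compound 4

A few compounds are considered here, and "the series" means these few. Any claim that something is new, unique, unknown or untested is made for them only; others in the source may bear on it.

Measured so far:
compound 1 `Cc1nc2c(CCc3ccccc3)cccn2c1N` 19%
compound 2 `Cc1nc2c(OCc3ccccc3)nccn2c1N` 63%
compound 3 `Cc1nc2c(/C=C\c3ccccc3)cccn2c1C` 25%

All three numbers come from a functional assay on the whole organism (stomach) for inhibition, with Canis familiaris (Canis lupus familiaris) as the target, at a dose of 2 mg/kg by the oral route; a lower number here means a weaker effect, a higher number a stronger effect of the compound at the dose given. Compound 3 stands second highest of the three. Its nearest neighbour on the numbers is compound 1, whose value lies lower by an amount within the usual scatter, so no order between compound 3 and compound 1 can be read. Compound 2 lies higher by an amount beyond the scatter.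

Compound 4 `Cc1nc2c(/C=C\c3ccccc3)cccn2c1N` is not yet measured. It differs from compound 3 in one place: amino in place of methyl on an aromatic carbon. Among the compounds with values here, no pair of measured compounds shows this change on its own, so the size of the step is open. Compound 1 carries the amino group and compound 3 the methyl group, and their values sit within the scatter of each other, though the two also differ elsewhere. The step of a number 5 percentage points higher from compound 3 to compound 4 (within the scatter) is therefore expected to be small, at most a slight rise. Compound 4 is estimated at 30%, with a range from 12% to 55% in this assay.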

Compound 4, a percentage reported as inhibition, in the whole organism at one dose (the size of the read-out at that dose, not a potency): 0%
Compound 4: middle estimate off by 30 percentage points, on the high side, outside the stated range (below it).
By their numbers in this assay, from the lowest: compound 4; then compounds 1 and 3 (each within the scatter of the next); then compound 2.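

In this assay, within the data shown here, amino in place of methyl on this aromatic carbon of the five-membered aromatic ring gives a number 25 percentage points lower from compound 3 to compound 4 (beyond the scatter), the first reading of this change on its own, and the step runs downward. With the rest of the structure held fixed, the methyl group is the better of the two at this position, and compound 4 gives 0%, so no inhibition is recorded with the amino group at the dose given. No measured finding accounts for the step.

On these data alone, this change has been read on one pair only, so whether the same drop holds with the other side chains, as carried by compound 1 and compound 2, stays open. Also open, as far as these compounds go, is how this position responds to groups such as an ethyl chain, a hydroxymethyl group or a bare hydrogen.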